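This account rests on a few compounds, and the source may have more. Where it says the series, first, only, none or still open, it means among the compounds named here.

In a physicochemical assay for lipophilicity, using the shake flask method, measured as octanol-water partition, at pH 7.4 (a lower number here means a more polar compound, a higher number a more lipophilic compound), the measured compounds read:
- compound 1 `CC(=O)N[C@H]1[C@H]([C@@H](O)[C@H](O)CNC(=O)c2ccc(Cl)cc2)O[C@@](OCc2ccc3ccccc3c2)(C(=O)O)C[C@@H]1O` gives 0.58
- compound 2 `O=C(CCl)N[C@H]1[C@H]([C@@H](O)[C@H](O)CNC(=O)c2ccc(Cl)cc2)O[C@@](OCc2cccc(F)c2F)(C(=O)O)C[C@@H]1O` gives 0.35

Compound 2 stands within the usual scatter of compound 1. Going by the values given here, the two differ in more than one place, and no measured step bears on the next change. Compound 3 `O=C(CC1CC1)N[C@H]1[C@H]([C@@H](O)[C@H](O)CNC(=O)c2ccc(Cl)cc2)O[C@@](OCc2cccc(F)c2F)(C(=O)O)C[C@@H]1O` differs from compound 2 as follows: cyclopropyl in place of chloro on a saturated chain carbon bound to a carbonyl carbon. With no measured guide, a modest rise in this assay is expected, perhaps only just beyond the scatter. The estimate is a number 0.35 log units higher from compound 2 to compound 3 (beyond the scatter) for this change. For compound 3 the estimated value is 0.7 (expected range 0.3 to 1.1).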

Compound 3, distribution coefficient: 0.31
Beside the measured number, compound 3's estimate is 0.39 log units above it; the range from low to high includes it.
By their numbers in this assay, from the lowest: compounds 3, 2 and 1 (each within the scatter of the next).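

Cyclopropyl in place of chloro on a saturated chain carbon bound to a carbonyl carbon gives a number 0.04 log units lower from compound 2 to compound 3 (within the scatter) in this assay, the first single-place step read at this position. Here, 3 heavy atoms of carbon with a three-membered ring replace 1 of chlorine without a step beyond the scatter. Nothing at hand bears on the reason for this result.

Still open, on these data alone, is how an amine, a carboxylic acid or a longer chain would read at this place. Also open, as far as these compounds go, is whether the same change gives a similar step on the core of compound 1.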